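A few compounds are considered here, and "the series" means these few. Any claim that something is new, unique, unknown or untested is made for them only; others in the source may bear on it.

For the measured compounds named here, in a functional assay on A549 cells (Homo sapiens) for antiproliferative activity, read by sulforhodamine B assay, with a stated time of 48 h (a lower number here means a stronger inhibitor of growth, a higher number a weaker inhibitor of growth), three compounds have numbers so far. Compound 1 `Cc1cc2c(cc1C)C(Cl)=C(C(=O)NNC(=S)Nc1ccccc1)CCC2` gives 759 nM, compound 2 `S=c1[nH]nc(C2=C(Cl)c3ccccc3CCC2)o1` gives 4960 nM, and compound 3 `ClC1=C(c2nnc(-c3ccccc3)o2)CCCc2ccccc21` gives 2270 nM. That places compound 3 second highest of the three numbers, and its gaps to both other compounds lie beyond the scatter.

Compound 4 `O=[N+]([O-])c1ccc(-c2nnc(C3=C(Cl)c4ccccc4CCC3)o2)cc1` differs from compound 3 in one place: nitro in place of hydrogen on an aromatic carbon. The nitro replaces hydrogen on an aromatic carbon of a six-membered aromatic ring of carbon only, para to a large group. Going by the values given here, no pair of measured compounds shows this change, so the data give no direct guide to its size or direction. The expectation therefore rests on compound 3 at 2270 nM as the closest reference, with a small shift towards a lower number in this assay and none beyond the scatter. The expected change is a 1.3-fold lower number from compound 3 to compound 4 (0.10 log units; within the scatter). For compound 4 the estimated value is 1800 nM, with an expected range from 600 nM to 5500 nM.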

Compound 4, concentration for 50% growth inhibition: 2610 nM
Compound 4: the middle estimate sits 1.5-fold (0.16 log units) below what was measured; the measured number falls inside the stated range.
By their numbers in this assay, from the lowest: compound 1; then compounds 3, 4 and 2 (each within the scatter of the next, the first and the last beyond it).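

In this assay, nitro in place of hydrogen on an aromatic carbon, para to a large group, gives a 1.1-fold higher number from compound 3 to compound 4 (0.06 log units; within the scatter) and so leaves compound 3 and compound 4 indistinguishable. This is the first step shown between compounds that differ in one place, and it shows that this position takes a group of 3 heavy atoms, with 2 hydrogen-bond acceptors, with no change in the number beyond the scatter. Nothing available explains this result.

On these data alone, a single group at a single place cannot show whether this position is insensitive in general, so it remains open whether an amine, a methoxy group or a carboxylic acid there would also read the same. As far as these compounds go, it also remains open whether nitro would give a similar step on the core of compound 1.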